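A fluoro to trifluoromethoxy swap on compound 3

The source may hold more compounds than are shown below. What is called first, only, known or untested is meant among the compounds shown, and "the series" means these compounds.

For the measured compounds named here, in a functional assay on VCaP cells (Homo sapiens) for antiproliferative activity, read by propidium iodide staining, with a stated time of 96 h (a higher number here means a weaker inhibitor, a lower number a stronger inhibitor), compound 3 (`CC(O)(CS(=O)(=O)c1ccc(F)cc1)C(=O)Nc1cccc(S(F)(F)(F)(F)F)c1`) gives 37900 nM and sits within the scatter of the two other compounds measured so far: compound 2 (`CC(O)(CS(=O)(=O)c1ccc(F)cc1)C(=O)Nc1ccc(S(F)(F)(F)(F)F)cc1`) gives 34200 nM and compound 1 (`CC(O)(CS(=O)(=O)c1cccc(S(F)(F)(F)(F)F)c1)C(=O)Nc1ccc([N+](=O)[O-])c(C(F)(F)F)c1`) gives 24600 nM on the same scale.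

Compound 4 (`CC(O)(CS(=O)(=O)c1ccc(OC(F)(F)F)cc1)C(=O)Nc1cccc(S(F)(F)(F)(F)F)c1`) changes compound 3 in a single place. It carries trifluoromethoxy in place of fluoro on an aromatic carbon, para to a large group, so that 4-fluorophenyl becomes 4-(trifluoromethoxy)phenyl (trifluoromethoxy in place of fluoro on an aromatic carbon).

Going by the values given here, no two measured compounds differ in just one place, so this swap has no direct precedent in the data. Among the compounds with values here, the only guide is how narrow the spread is so far. Compound 1 at 24600 nM and compound 3 at 37900 nM are the pair furthest apart, and even they stay within the scatter.

A small step is therefore expected, a 1.5-fold lower number from compound 3 to compound 4 (0.18 log units; within the scatter) in this assay as the estimate, leaning towards a somewhat lower number but not clearly beyond the scatter. In this assay the estimate for compound 4 is 25000 nM with an expected range from 10000 nM to 55000 nM as its bounds.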

Compound 4, half-maximal inhibitory concentration: 15100 nM
The estimate for compound 4 lay 1.7-fold (0.22 log units) above the measured number; the range from low to high includes it.
By their numbers in this assay, from the lowest: compounds 4, 1, 2 and 3 (each within the scatter of the next, the first and the last beyond it).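

Exchanging 4-fluorophenyl for 4-(trifluoromethoxy)phenyl gives, in this assay, a 2.5-fold lower number from compound 3 to compound 4 (0.40 log units; beyond the scatter), the first step among these compounds that can be read as a real change, so this aromatic carbon, para to a large group, is a place where a substitution can shift the number. The step is modest and rests on a single pair of compounds, so it shows a direction for this one swap and not a trend across the series. Nothing measured here bears on why the number fell.

The compounds shown leave open which part of the new group matters, the oxygen or the three fluorines, or simply its larger size; a methoxy group or a plain chlorine on the same carbon would help to separate these possibilities. As far as these compounds go, it is also open whether the same swap would give a similar step on compound 2, which carries the same 4-fluorophenyl group but differs from compound 3 on the other aromatic ring.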